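A few compounds are considered here, and "the series" means these few. Any claim that something is new, unique, unknown or untested is made for them only; others in the source may bear on it.

Compound 3 `CC(C)CNCC(=O)N1N=C(c2cc3ccccc3oc2=O)CC1c1ccccc1` gives the lowest number of the three measured compounds in a functional assay on PC-3 cells (Homo sapiens) for cytotoxicity, read by MTT assay, with a stated time of 48 h (a higher number here means a weaker inhibitor, a lower number a stronger inhibitor), at 1920 nM. Compound 2 `CCCNCC(=O)N1N=C(c2cc3ccccc3oc2=O)CC1c1ccccc1` gives 7270 nM and compound 1 `Cc1ccc(S(=O)(=O)N2N=C(c3cc4ccccc4oc3=O)CC2c2ccccc2)cc1` gives 48600 nM; the step of a 25-fold lower number from compound 1 to compound 3 (1.40 log units; beyond the scatter) is the largest shown, and a 3.8-fold lower number from compound 2 to compound 3 (0.58 log units; beyond the scatter) and a 6.7-fold lower number from compound 1 to compound 2 (0.83 log units; beyond the scatter) are both modest. Compound 4 `CC1CCCCN1CC(=O)N1N=C(c2cc3ccccc3oc2=O)CC1c1ccccc1` carries a different amine: 2-methylpiperidin-1-yl in place of isobutylamino on a saturated chain carbon bound to a carbonyl carbon. Going by the values given here, no measured step changes the amine in this way; the only nearby step, a 3.8-fold lower number from compound 2 to compound 3 (0.58 log units; beyond the scatter), adds a branch on the chain but keeps the amine hydrogen. Compound 4 is therefore expected to show a 1.3-fold higher number from compound 3 to compound 4 (0.11 log units; within the scatter), with no step beyond the scatter foreseen. The estimate for compound 4 is 2500 nM, within a range of 700 nM to 9000 nM.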

Compound 4, half-maximal inhibitory concentration: 36300 nM
Compound 4: middle estimate off by 15-fold (1.16 log units), on the low side; the measured number lies above the stated range.
By their numbers in this assay, from the lowest: compound 3; then compound 2; then compounds 4 and 1 (each within the scatter of the next).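

In this assay, the amine at this position matters more than the earlier branch on the chain suggested: 2-methylpiperidin-1-yl in place of isobutylamino gives a large step (a 19-fold higher number from compound 3 to compound 4 (1.28 log units; beyond the scatter)), and in place of propylamino a modest one (a 5.0-fold higher number from compound 2 to compound 4 (0.70 log units; beyond the scatter)). The ((2-methylpiperidin-1-yl)methyl)carbonyl group also does not separate from the (4-methylphenyl)sulfonyl group (a 1.3-fold lower number from compound 1 to compound 4 (0.13 log units; within the scatter)), so this acyl group does not by itself give the lower numbers seen with the two secondary amines. No available evidence accounts for this result.

The compounds shown leave open whether the ring, its methyl or the loss of the amine hydrogen governs the step. Piperidin-1-yl and cyclohexylamino at this position could separate these.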